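Swapping the Amide Cap on a Shared Core

This account rests on a few compounds, and the source may have more. Where it says the series, first, only, none or still open, it means among the compounds named here.

Compound 1, `NS(=O)(=O)CC(=O)NCCSc1nonc1/C(=N/O)Nc1ccc(F)c(C(F)F)c1`: 13 nM
Compound 2, `O=C(NCCSc1nonc1/C(=N/O)Nc1ccc(F)c(C(F)F)c1)C1CS(=O)(=O)C1`: 13 nM

In an assay for inhibition of Indoleamine 2,3-dioxygenase 1 (Homo sapiens), read by fluorescence, with a stated time of 24 h (on this read-out lower numbers stand for stronger inhibition and higher numbers for weaker inhibition), compound 2 gives 13 nM, level with compound 1 at the digits shown. Compound 3, `N#CCC(=O)NCCSc1nonc1/C(=N/O)Nc1ccc(F)c(C(F)F)c1`, differs from compound 2 by a group of 3 heavy atoms (2 carbon, 1 nitrogen; no ring) in place of a group of 6 heavy atoms (3 carbon, 2 oxygen, 1 sulfur; one four-membered non-aromatic ring with 1 hetero atom), on a carbonyl carbon. Among the compounds with values here, the one measured step at this carbonyl carbon, no change at the digits printed from compound 1 to compound 2 (within the scatter), exchanged one cap for another without moving this assay beyond the scatter. Within the data shown here, with only that step to lean on, the expected step of a 1.5-fold higher number from compound 2 to compound 3 (0.19 log units; within the scatter) is small, no change beyond the scatter or at most a slight weakening. Compound 3 is therefore estimated at 20 nM, with a range from 8 nM to 50 nM.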

Compound 3, half-maximal inhibitory concentration: 6.5 nM
The estimate for compound 3 lay 3.1-fold (0.49 log units) above the measured number; the whole stated range lies above it.
By their numbers in this assay, from the lowest: compounds 3, 1 and 2 (each within the scatter of the next).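

In this assay, a much smaller cap on the carbonyl carbon does as well as the two larger ones: cyanomethyl, with 3 heavy atoms and no ring, gives a 2.0-fold lower number from compound 2 to compound 3 (0.30 log units; within the scatter) and a 2.0-fold lower number from compound 1 to compound 3 (0.30 log units; within the scatter). All three caps shown therefore read alike at this position, whether they carry a nitrile, a sulfamoyl group or a four-membered ring. No measurement available here explains this result. Still open, going by these compounds, is how an amine, a carboxylic acid or a longer chain on this carbonyl carbon would read. On these data alone, a plain methyl cap with no hetero atom is equally open.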